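The compounds below may be only part of what the source reports. "The series", "measured", "known", "first", "only" and "open" are said of these compounds alone.

Measured compounds: compound 1 is `Cc1ccc(-c2oc3ccc(C(=O)O)cc3c(=O)c2O)cc1` and gives 6%. Compound 2 is `CC(C)c1ccc(-c2oc3ccc(C(=O)O)cc3c(=O)c2O)cc1` and gives 24%. Compound 3 is `COc1ccc(-c2oc3ccc(C(=O)O)cc3c(=O)c2O)cc1` and gives 24%.

In a functional assay on the whole organism (stomach) for inhibition, with Rattus norvegicus as the target, at a dose of 80 mg/kg (a higher number here means more inhibition at the dose given (going by the name of the read-out), a lower number less inhibition), compound 3 stands level with compound 2, and the two together hold the highest of the three numbers; the remaining compound sits lower by the step of a number 18 percentage points higher from compound 1 to compound 3 (beyond the scatter). Compound 4 is `CCCCCCOc1ccc(-c2oc3ccc(C(=O)O)cc3c(=O)c2O)cc1`, and it differs from compound 3 by pentyl in place of hydrogen on a saturated chain carbon bound to an oxygen on an aromatic ring. Within the data shown here, no measured step lengthens a chain of this kind. The nearest guide is a number 18 percentage points higher from compound 1 to compound 2 (beyond the scatter), where isopropyl in place of methyl on the aromatic carbon went with a higher number, whereas no change at the digits printed from compound 2 to compound 3 (within the scatter) shows that exchanging groups can also leave the number unchanged. A small rise, or nothing beyond the scatter, is therefore expected, a number 6 percentage points higher from compound 3 to compound 4 (within the scatter). Compound 4 is estimated at 30%, within the range 10% to 55%.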

Compound 4, a percentage reported as inhibition, in the whole organism at one dose (the size of the read-out at that dose, not a potency): -11%
The estimate for compound 4 lay 41 percentage points above the measured number, outside the stated range (below it).
By their numbers in this assay, from the lowest: compound 4; then compound 1; then compounds 2 and 3 (each within the scatter of the next).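

In this assay, among these compounds, the lengthening of methoxy to hexyloxy brings a number 35 percentage points lower from compound 3 to compound 4 (beyond the scatter) and is the first change at this position to go with a lower number. Hexyloxy also ends under the smaller groups, with a number 35 percentage points lower from compound 2 to compound 4 (beyond the scatter) and with a number 17 percentage points lower from compound 1 to compound 4 (beyond the scatter) as well, so the rise seen with isopropyl and methoxy does not carry on to this chain. Nothing available here accounts for this fall. From the compounds shown here alone, whether a shorter chain such as butoxy keeps the number of compound 3 remains open. So does the effect of an amine at the end of the hexyl chain.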